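Swapping the chloro-bearing ring for a methylsulfonyl ring

The source may hold more compounds than are shown below. What is called first, only, known or untested is meant among the compounds shown, and "the series" means these compounds.

The compounds share one core, differing only in the ring attached to the carbonyl carbon. For the measured compounds named here, compound 1 `O=C(Nc1ccc(Cl)c(-c2nnc3c(Cl)cccn23)c1)c1cccc(Cl)c1` is the only compound with a number: in a functional assay on T47D cells (Homo sapiens) for antiproliferative activity, read by MTT assay, with a stated time of 72 h (a higher number here means a weaker inhibitor, a lower number a stronger inhibitor), compound 1 gives 30200 nM. Compound 2 `O=C(Nc1ccc(Cl)c(-c2nnc3c(Cl)cccn23)c1)c1c(F)cccc1Cl` reaches only a limit of the assay, > 100000 nM. Compound 3 `O=C(Nc1ccc(Cl)c(-c2nnc3c(Cl)cccn23)c1)c1ccc(Cl)cc1Cl` likewise reaches only a limit, > 100000 nM. The steps of an at least 3.3-fold higher number from compound 1 to compound 2 (0.51 log units; beyond the scatter) and an at least 3.3-fold higher number from compound 1 to compound 3 (0.51 log units; beyond the scatter) both weaken the compound when the 3-chlorophenyl is replaced, with the limit of > 100000 nM in this assay, at which 2 of the 3 values shown sit, marking the ceiling. Compound 4 `CS(=O)(=O)c1ccc(C(=O)Nc2ccc(Cl)c(-c3nnc4c(Cl)cccn34)c2)cc1` changes the same ring: 4-(methylsulfonyl)phenyl in place of 3-chlorophenyl on a carbonyl carbon. Since both earlier replacements weakened activity, a further weakening is expected, roughly a 2.6-fold higher number from compound 1 to compound 4 (0.42 log units; beyond the scatter). Compound 4 is therefore estimated at 80000 nM, within 25000 nM to 250000 nM, quite possibly reported only as a limit.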

Compound 4, half-maximal inhibitory concentration: > 100000 nM
Compound 4 gave a limit, no number; the forecaster's own chance of this, stated with the estimate: 50%; at least 1.2-fold (0.09 log units) between middle value and limit.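

Unlike the two earlier replacements, the 4-(methylsulfonyl)phenyl ring carries no chlorine and brings hydrogen-bond acceptors, yet this assay still shows an at least 3.3-fold higher number from compound 1 to compound 4 (0.51 log units; beyond the scatter). Among these four compounds, then, only the 3-chlorophenyl ring gives a number, and replacement rings with and without chlorine both fall short of it. The steps among compound 2, compound 3 and compound 4 cannot be read, since all three sit at one limit: the limit of > 100000 nM in this assay, at which 3 of the 4 values shown sit.

As far as these compounds go, whether any ring on this carbonyl carbon improves on compound 1 stays open. A 3-methoxyphenyl or 3-aminophenyl ring would show whether the chlorine itself matters.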